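Second chlorine on the fused core: growth inhibition notes

The source may hold more compounds than are shown below. What is called first, only, known or untested is meant among the compounds shown, and "the series" means these compounds.

Three compounds of the series have been run in a functional assay on LOX IMVI cells (Homo sapiens) for cytotoxicity, read by sulforhodamine B assay, with a stated time of 48 h; a lower number here means a stronger inhibitor of growth, a higher number a weaker inhibitor of growth. Compound 1 `ClCc1ccccc1Cn1cnc2c(Cl)nc(Cl)nc21` gives 360 nM. Compound 2 `ClCc1ccccc1Cn1cnc2c(Cl)ncnc21` gives 5240 nM. Compound 3 `ClCc1ccccc1Cn1cnc2ncnc(Cl)c21` gives 3090 nM. Compound 2 and compound 3 share the same atoms joined differently; the difference between the two cores is not broken down here, and their values lie within the usual scatter of each other. Compound 3 and compound 1 differ beyond the scatter, the value of compound 1 being the lower of the two.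

The change from compound 2 to compound 1 is chloro in place of hydrogen on an aromatic carbon, and it made a step of a 15-fold lower number from compound 2 to compound 1 (1.16 log units; beyond the scatter). Compound 4 `ClCc1ccccc1Cn1cnc2nc(Cl)nc(Cl)c21` has not been measured; it differs from compound 3 by chloro in place of hydrogen on an aromatic carbon, which is the same change made on the core of compound 3, with an identical place description.

Within the data shown here, for compound 4 in this assay a step of a 10-fold lower number from compound 3 to compound 4 (1.01 log units; beyond the scatter) is expected, resting on the single earlier example, because a 15-fold lower number from compound 2 to compound 1 (1.16 log units; beyond the scatter) was observed for the same change. Among the measured compounds shown here, the estimate for compound 4 is therefore 300 nM, with a range from 100 nM to 1000 nM, the width reflecting that only one prior instance supports the transfer between cores.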

Compound 4, concentration for total growth inhibition: 350 nM
For compound 4 the middle estimate is 1.2-fold (0.07 log units) below the measured one; low and high end bracket the measured number.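

In this assay, chloro in place of hydrogen on an aromatic carbon, here between two ring nitrogen atoms, made an 8.8-fold lower number from compound 3 to compound 4 (0.95 log units; beyond the scatter). The step carried over to the second core with its size held, within the scatter of the earlier step: the same change on two cores in this assay, a 15-fold lower number (1.16 log units; beyond the scatter) from compound 2 to compound 1 and an 8.8-fold lower number (0.95 log units; beyond the scatter) from compound 3 to compound 4, 1.6-fold (0.22 log units) apart, within the scatter of two such steps. Among these compounds, this rests on only two cores, one cell line and one stated time, so it supports transfer between these two cores alone, sets no rule for any other core, and gives no account of why the number falls.

Going by these compounds, whether chloro is specifically required in that place remains open, and an amine, a methoxy group or a bromo group there would test this on both cores. The chloromethyl group is present in all the compounds shown, so its contribution cannot be judged, and a hydroxymethyl group or a plain methyl group in its place would be the direct comparison.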